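From compound 3 to compound 4: one group exchanged

The source may hold more compounds than are shown below. What is called first, only, known or untested is meant among the compounds shown, and "the series" means these compounds.

In a physicochemical assay for lipophilicity, using the shake flask method, in phosphate buffer, measured as octanol-water partition, with a stated time of 30 min, at pH 7.4 (on this read-out lower numbers stand for lower lipophilicity and higher numbers for higher lipophilicity), compound 3 `Cc1ncccc1-c1cnc(NCc2c(F)ccc3c2CCO3)c2cn[nH]c(=O)c12` gives 3. Compound 1 `Cn1cc(-c2cnc(NCc3c(F)ccc4c3CCO4)c3cn[nH]c(=O)c23)cn1` gives 2.7, and compound 2 `CN(C)C(=O)c1cc(-c2cnc(NCc3c(F)ccc4c3CCO4)c3cn[nH]c(=O)c23)n(C)n1` gives 2.1. The gaps that place compound 3 are a number 0.30 log units higher from compound 1 to compound 3 (within the scatter) and a number 0.90 log units higher from compound 2 to compound 3 (beyond the scatter), so only the second is a real difference.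

Compound 4 `CNC(=O)c1ncc(-c2cnc(NCc3c(F)ccc4c3CCO4)c3cn[nH]c(=O)c23)n1C` carries 1-methyl-2-(methylcarbamoyl)-1H-imidazol-5-yl in place of 2-methylpyridin-3-yl on an aromatic carbon.

The nearest guide is compound 2, whose 3-(dimethylcarbamoyl)-1-methyl-1H-pyrazol-5-yl also holds a carbamoyl group, with a modest step of a number 0.60 log units lower from compound 1 to compound 2 (beyond the scatter). A downward move of similar size to the gap between compound 2 and compound 3 is therefore expected, giving an estimated a number 1.00 log units lower from compound 3 to compound 4 (beyond the scatter). For compound 4 the estimate is 2, with an expected range of 1.5 to 2.5.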

Compound 4, distribution coefficient: 2.5
Compound 4: middle estimate off by 0.50 log units, on the low side; measured number inside the range.
By their numbers in this assay, from the lowest: compound 2; then compounds 4, 1 and 3 (each within the scatter of the next, the first and the last beyond it).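

In this assay, replacing 2-methylpyridin-3-yl with 1-methyl-2-(methylcarbamoyl)-1H-imidazol-5-yl gives a number 0.50 log units lower from compound 3 to compound 4 (beyond the scatter) at this position. The two carbamoyl-bearing groups also read differently (a number 0.40 log units higher from compound 2 to compound 4 (beyond the scatter)), and only the group in compound 2 is separated from 1-methyl-1H-pyrazol-4-yl (a number 0.20 log units lower from compound 1 to compound 4 (within the scatter)). No measurement available here explains that difference.

From the compounds shown here alone, the ring, the place of the carbamoyl group and its number of methyl groups all change together between compound 2 and compound 4, so their separate shares stay open. Going by these compounds, how a carboxylic acid or an amine in place of the carbamoyl group would read also stays open.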